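A nitro group in place of dimethylamino on the aryl ring

This account rests on a few compounds, and the source may have more. Where it says the series, first, only, none or still open, it means among the compounds named here.

Two compounds sharing a core have been examined so far. Compound 1 `Cc1ccc2nc(-c3ccc(N(C)C)cc3)c(NC3CCCCC3)n2c1` was tested in an assay on cells for inhibition of Polyunsaturated fatty acid 5-lipoxygenase (Homo sapiens), read by HPLC, with stated times of 15 min and 10 min (on this read-out higher numbers stand for weaker inhibition and lower numbers for stronger inhibition), where compound 1 gives 600 nM. Compound 2 `Oc1ccc(-c2nc3ccc(Br)cn3c2NC2CCCCC2)cc1` carries a different set of substituents on the same core; in this assay compound 2 gives 1100 nM. Going by the values given here, the two numbers lie within the usual scatter of each other, so neither compound can be set apart from the other on this read-out, and no single-point step between measured compounds is available to guide expectations.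

Compound 3 `Cc1ccc2nc(-c3ccc([N+](=O)[O-])cc3)c(NC3CCCCC3)n2c1` is the next compound to be measured. It differs from compound 1 in one place: nitro in place of dimethylamino on an aromatic carbon. The core and the cyclohexylamino substituent are unchanged.

Among the compounds with values here, with no measured step of this kind to draw on, only a modest step is expected from compound 1 to compound 3 in this assay, with weaker inhibition somewhat more likely than stronger, as a 1.7-fold higher number from compound 1 to compound 3 (0.22 log units; within the scatter). Compound 3 is therefore estimated at 1000 nM, within a range from 300 nM to 3500 nM.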

Compound 3, half-maximal inhibitory concentration: 1530 nM
Compound 3: the middle estimate sits 1.5-fold (0.18 log units) below what was measured; the measured number falls inside the stated range.
By their numbers in this assay, from the lowest: compounds 1, 2 and 3 (each within the scatter of the next, the first and the last beyond it).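

Going by these compounds alone, this is the first change at a single place, and it shows that the group on this aromatic carbon, para to a large group, can move the read-out: in this assay, nitro in place of dimethylamino gives a 2.6-fold higher number from compound 1 to compound 3 (0.41 log units; beyond the scatter). The step is modest but beyond the scatter, with weaker inhibition on the nitro side, so this position is not indifferent to the exchange, although dimethylamino is not shown to be needed for inhibition, since compound 3 still has a number in the same assay. Nothing at hand accounts for the step, so the data give the direction and size of this one exchange and no reason for it.

Going by these compounds, one pair cannot show whether the step follows from losing dimethylamino or from bringing in nitro, and it remains open where a primary amine or a methoxy group on the same aromatic carbon would fall relative to these two groups. Also open, on these data alone, is whether the same exchange would give a step of similar size with bromo in place of the methyl group on the shared core.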